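Chlorine Returns on the Ring Bound to Nitrogen

The source may report more compounds than this note shows. Statements on the series, on what has been measured and on what is new or still open speak of the compounds shown alone.

Measured so far:
compound 1, `CC(C(=O)N1CCN(c2cccc(Cl)c2)CC1)N1C(=O)CCC1=O` — 100%
compound 2, `CC(C(=O)N1CCN(c2cccc(F)c2)CC1)N1C(=O)CCC1=O` — 50%

Both compounds were tested in a functional assay on the whole organism (strain Swiss) with Mus musculus as the target, in the maximal electroshock model, with a stated time of 0.5 h, at a dose of 300 mg/kg by the intraperitoneal route; on this read-out higher numbers stand for a stronger effect at the one dose given and lower numbers for a weaker effect. Compound 1 gives 100% there, while compound 2 gives 50%, the lower of the two numbers. Among the measured compounds shown here, the single measured step, a number 50 percentage points lower from compound 1 to compound 2 (beyond the scatter), came with fluoro in place of chloro on an aromatic carbon, and it is the only step available to draw on. Compound 3, `CC(C(=O)N1CCN(c2ccccc2Cl)CC1)N1C(=O)CCC1=O`, has not been measured. It differs from compound 2 by 2-chlorophenyl in place of 3-fluorophenyl on an amine nitrogen in a ring. For the measured compounds named here, this brings chlorine back in place of fluorine, though 2-chlorophenyl is not the same group that compound 1 carries, and no measured pair covers that difference. Since the move from chloro to fluoro cost a number 50 percentage points lower from compound 1 to compound 2 (beyond the scatter), the return to chloro is expected to win much of that back, so the expected step is a number 35 percentage points higher from compound 2 to compound 3 (beyond the scatter), upward and beyond the scatter. Compound 3 is therefore estimated at 85%, within a range from 55% to 100%. The change in the chlorophenyl group itself leaves that range wide.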

Compound 3, a percentage reported as activity, at one dose (the size of the read-out at that dose, not a potency): 0%
Compound 3: the middle estimate sits 85 percentage points above what was measured; measured number below the stated range.
By their numbers in this assay, from the lowest: compound 3; then compound 2; then compound 1.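

In this assay the result shows that, on the aromatic ring bound to the amine nitrogen, the identity of the halogen is not the only thing that matters: where it sits on the ring matters too. With 2-chlorophenyl in place of 3-chlorophenyl, chlorine is still present, yet the change brings a number 100 percentage points lower from compound 1 to compound 3 (beyond the scatter) and spans the whole range of values seen in these compounds. Chlorine alone therefore does not secure the effect: 2-chlorophenyl in place of 3-fluorophenyl gives a number 50 percentage points lower from compound 2 to compound 3 (beyond the scatter) even though chlorine replaces fluorine, but this step changes both the halogen and its place on the ring, so it cannot separate the two.

The compounds shown leave open how a plain phenyl group with no halogen, or a methoxy group on the same ring, would compare in this assay, and whether fluorine in the 2-fluorophenyl arrangement would also end with no effect at this dose. Nothing available explains why the effect disappears in compound 3.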